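Bromophenyl positional swap on the triazole nitrogen of the diaryl urea

The source may hold more compounds than are shown below. What is called first, only, known or untested is meant among the compounds shown, and "the series" means these compounds.

Compound 1 `O=C(Nc1cccc(OCc2cn(-c3ccc(F)cc3)nn2)c1)Nc1ccc(Cl)c(C(F)(F)F)c1` and compound 2 `O=C(Nc1cccc(OCc2cn(-c3cccc(Br)c3)nn2)c1)Nc1ccc(Cl)c(C(F)(F)F)c1` share the diaryl urea core and differ only in the aryl group on the triazole nitrogen. Going by the values given here, in a toxicity assay on MRC5 cells (Homo sapiens) for inhibition, read by MTT assay, with a stated time of 72 h (a lower number here means a stronger inhibitor, a higher number a weaker inhibitor), compound 1 gives 4740 nM, while compound 2 gives 11900 nM; this makes compound 2 the highest of the two numbers measured so far, the step being a 2.5-fold higher number from compound 1 to compound 2 (0.40 log units; beyond the scatter). Compound 3 `O=C(Nc1cccc(OCc2cn(-c3ccc(Br)cc3)nn2)c1)Nc1ccc(Cl)c(C(F)(F)F)c1` has not yet been measured in this assay. Its difference from compound 2 is 4-bromophenyl in place of 3-bromophenyl on an aromatic nitrogen, so the bromine simply moves within the same ring. Among the compounds with values here, the only measured step that bears on this, from compound 1 to compound 2, combined a change of halogen with a change of position and was modest, so no firm reading for a pure positional move exists. The step of a 1.6-fold lower number from compound 2 to compound 3 (0.20 log units; within the scatter) is therefore expected to be small, at most a slight lowering, and compound 3 is estimated at 7500 nM in this assay, with a range from 3000 nM to 18000 nM.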

Compound 3, half-maximal inhibitory concentration: 11000 nM
Compound 3: middle estimate off by 1.5-fold (0.17 log units), on the low side; the measured number falls inside the stated range.
By their numbers in this assay, from the lowest: compound 1; then compounds 3 and 2 (each within the scatter of the next).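

In this assay, moving the bromine within the ring gives a 1.1-fold lower number from compound 2 to compound 3 (0.03 log units; within the scatter), so 3-bromophenyl and 4-bromophenyl on the aromatic nitrogen cannot be told apart in this read-out. With the ring position held constant, bromo in place of fluoro on the aromatic carbon gives a 2.3-fold higher number from compound 1 to compound 3 (0.37 log units; beyond the scatter); this separates the halogen change from the positional move that were combined in the earlier step and shows that the halogen change alone goes beyond the scatter. No measurement is available to explain either step.

On these data alone, two halogens do not establish a trend, so it remains open where chloro, methoxy or an amine on this phenyl ring would fall. As far as these compounds go, it also remains open whether a carboxylic acid or an unsubstituted phenyl would fall nearer compound 1 or nearer compound 2 and compound 3.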